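Replacing the Dihydroxypropyl Triazole with a Methylpiperazine Chain

A few compounds are considered here, and "the series" means these few. Any claim that something is new, unique, unknown or untested is made for them only; others in the source may bear on it.

In a functional assay on A-375 cells (Homo sapiens) for cytotoxicity, read by MTT assay, with a stated time of 72 h (on this read-out higher numbers stand for weaker inhibition and lower numbers for stronger inhibition), compound 1 (`CN(C)CCCCCn1c2c(c3ccccc31)C(=O)c1c[n+]([O-])c3ccccc3c1C2=O`) gives 560 nM while compound 2 (`O=C1c2c[n+]([O-])c3ccccc3c2C(=O)c2c1c1ccccc1n2Cc1cn(C[C@H](O)CO)nn1`) gives 350 nM and compound 3 (`O=C1c2c[n+]([O-])c3ccccc3c2C(=O)c2c1c1ccccc1n2Cc1cn(CC(O)CO)nn1`) gives 440 nM on the shared core. All three lie within the scatter of one another, so compound 3 holds no distinct place among them. Compound 4 (`CN1CCN(CCCCn2c3c(c4ccccc42)C(=O)c2c[n+]([O-])c4ccccc4c2C3=O)CC1`) carries 3-(4-methylpiperazin-1-yl)propyl in place of 1-(2,3-dihydroxypropyl)-1H-1,2,3-triazol-4-yl on a saturated chain carbon bound to an aromatic nitrogen. The nearest measured comparison runs the other way: the 1-(2,3-dihydroxypropyl)-1H-1,2,3-triazol-4-yl group replaced 4-(dimethylamino)butyl in two small steps (a 1.3-fold lower number from compound 1 to compound 3 (0.10 log units; within the scatter)) and (a 1.6-fold lower number from compound 1 to compound 2 (0.20 log units; within the scatter)). A third step (a 1.3-fold higher number from compound 2 to compound 3 (0.10 log units; within the scatter)) is just as small, and the only difference there is (the fact that one of compounds 2 and 3 is drawn with a defined configuration and the other without, at the place where they differ). Going by the values given here, no measured compound carries the piperazine ring, so the comparison is only indirect, and no step beyond the scatter is expected in this assay here. The expected step is (a 1.1-fold higher number from compound 3 to compound 4 (0.06 log units; within the scatter)). For compound 4 the estimated value is 500 nM with an expected range from 200 nM to 1200 nM in this measurement.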

Compound 4, half-maximal inhibitory concentration: 30 nM
Estimate against measurement, compound 4: 17-fold (1.22 log units) above; measured number outside the range, below it.
By their numbers in this assay, from the lowest: compound 4; then compounds 2, 3 and 1 (each within the scatter of the next).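

In this assay, this place, on a saturated chain carbon bound to an aromatic nitrogen, turns out to be sensitive to the group it carries: 3-(4-methylpiperazin-1-yl)propyl in place of 1-(2,3-dihydroxypropyl)-1H-1,2,3-triazol-4-yl gives large steps (a 15-fold lower number from compound 3 to compound 4 (1.17 log units; beyond the scatter)) and (a 12-fold lower number from compound 2 to compound 4 (1.07 log units; beyond the scatter)), where every earlier step stayed within the scatter. An amine at the chain end does not by itself set compound 4 apart, since 4-methylpiperazin-1-yl in place of (dimethylamino)methyl also gives a large step (a 19-fold lower number from compound 1 to compound 4 (1.27 log units; beyond the scatter)). Nothing measured here bears on why this step is so large.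

The compounds shown leave open whether the ring or its methyl group matters, as a piperazine without the methyl or a morpholine would test. They also leave open how a shorter or longer chain carrying the 4-methylpiperazin-1-yl group would compare.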